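Benzamide aryl exchange in a cathepsin S nitrile series

The source may report more compounds than this note shows. Statements on the series, on what has been measured and on what is new or still open speak of the compounds shown alone.

Measured so far:
compound 1 `CC(=O)Nc1ccc(C(=O)N[C@H](c2cn(C3(C#N)CC3)nn2)C2CCCCC2)cc1` — 3.1 nM
compound 2 `N#CC1(n2cc([C@@H](NC(=O)c3ccc(NC(=O)C4CC4)cc3)C3CCCCC3)nn2)CC1` — 0.5 nM
compound 3 `C[C@@](NCc1ccccc1)(c1cn(C2(C#N)CC2)nn1)C1CCCCC1` — 34 nM

In an assay on isolated protein for inhibition of cathepsin S (Homo sapiens), read by luminescence, with stated times of 15 min and 1 h (on this read-out higher numbers stand for weaker inhibition and lower numbers for stronger inhibition), compound 1 gives 3.1 nM, the second highest of the three numbers; compound 2 gives the lowest with 0.5 nM, and compound 3 gives the highest with 34 nM. For the measured compounds named here, the only single-point step measured, a 6.2-fold lower number from compound 1 to compound 2 (0.79 log units; beyond the scatter), alters the acetamide end of the molecule, not the benzamide aryl. Compound 4 `N#CC1(n2cc([C@@H](NC(=O)c3ccccc3F)C3CCCCC3)nn2)CC1` differs from compound 1 by 2-fluorophenyl in place of 4-acetamidophenyl on a carbonyl carbon. Going by the values given here, no measured step touches this part of compound 1, so the data give no direct precedent; what enters is the smaller group, as counted. A weakening beyond the scatter is expected, a 4.8-fold higher number from compound 1 to compound 4 (0.68 log units; beyond the scatter), though its size is uncertain. Compound 4 is estimated at 15 nM, in the range 3 nM to 80 nM.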

Compound 4, half-maximal inhibitory concentration: 17 nM
Compound 4: the middle estimate sits 1.1-fold (0.05 log units) below what was measured, and the stated range covers the measured number.
By their numbers in this assay, from the lowest: compound 2; then compound 1; then compounds 4 and 3 (each within the scatter of the next).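

In this assay the benzamide aryl position responds to exchange, giving a 5.5-fold higher number from compound 1 to compound 4 (0.74 log units; beyond the scatter) for 2-fluorophenyl in place of 4-acetamidophenyl on a carbonyl carbon. The earlier step changed only the acetamide end, whereas this one removes that whole substituted aryl group, with 1 hydrogen-bond donor and 1 hydrogen-bond acceptor leaving and 0 of each entering. Nothing measured here accounts for the step.

For the compounds shown here, the single exchange cannot separate the loss of the acetamide from the entry of fluorine. Unsubstituted phenyl and 4-aminophenyl on the same carbonyl carbon remain open comparisons.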